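Triazole linked aryl pairs and an aminophenyl swap

The source may hold more compounds than are shown below. What is called first, only, known or untested is meant among the compounds shown, and "the series" means these compounds.

The series is followed in a functional assay on MDA-MB-231 cells (Homo sapiens) for cytotoxicity, read by MTT assay; a lower number here means a stronger inhibitor, a higher number a weaker inhibitor. Compound 1, `COc1cc(-n2cc(-c3ccc(N)cc3)nn2)cc(OC)c1OC`, reaches only the limit of the assay, > 10000 nM. Compound 2, `COc1cc(-n2cc(-c3cc(O)cc(O)c3)nn2)cc(OC)c1OC`, likewise gives only the limit > 10000 nM. The change between them, (4-aminophenyl in place of 3,5-dihydroxyphenyl on an aromatic carbon), therefore yields a step that the two limits leave unreadable, a step that the two limits leave unreadable from compound 2 to compound 1, and this rests on (the limit of > 10000 nM in this assay, at which 3 of the 3 values shown sit). Compound 3, `Oc1cc(O)cc(-c2cn(-c3ccc(Oc4ccccc4)cc3)nn2)c1`, also stops at the limit > 10000 nM. How the core of compound 3 differs from the core of compound 2 is not broken down here. Compound 4, `Nc1ccc(-c2cn(-c3ccc(Oc4ccccc4)cc3)nn2)cc1`, has not yet been measured in this assay; it carries the same change as before, (4-aminophenyl in place of 3,5-dihydroxyphenyl on an aromatic carbon). Since the earlier instance of this change gave only an unreadable step, and all three measured compounds sit at the limit, the step from compound 3 to compound 4 is expected to be small, about a step that the limit leaves unreadable from compound 3 to compound 4. For compound 4 the estimated value in this assay is 20000 nM, with an expected range from 8000 nM to 60000 nM.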

Compound 4, half-maximal inhibitory concentration: > 10000 nM
Compound 4 ended at the assay's limit; the forecaster's own chance of this, stated with the estimate: 80%; the middle value is on the limit's open side.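

Going by these compounds alone, compound 3 and compound 4 both stop at the limit of this assay, so the change to 4-aminophenyl gives no step that can be read between them: the limit of > 10000 nM in this assay, at which 4 of the 4 values shown sit.

The compounds shown leave open how, in this assay, this change from 3,5-dihydroxyphenyl to 4-aminophenyl would act on a compound with a readable value.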